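Swapping methyl for cyclohexyl on the amino compound

The source may report more compounds than this note shows. Statements on the series, on what has been measured and on what is new or still open speak of the compounds shown alone.

In an ADME assay on MT4 cells (Homo sapiens) for cytotoxicity, read by MTT assay, with a stated time of 96 h (on this read-out higher numbers stand for lower toxicity in this test and lower numbers for higher toxicity in this test), compound 1 `Cn1c(-c2ccc([N+](=O)[O-])cc2)nc2cc(C(F)(F)F)ccc21` gives >= 100000 nM, which is a limit of the assay and not a number. Compound 2 `O=[N+]([O-])c1ccc(-c2nc3cc(C(F)(F)F)ccc3n2C2CCCCC2)cc1` gives 49000 nM. Going by the values given here, compound 3 `Cn1c(-c2ccc(N)cc2)nc2cc(C(F)(F)F)ccc21` holds the lowest number so far, at 20000 nM. Compound 4 `Nc1ccc(-c2nc3cc(C(F)(F)F)ccc3n2C2CCCCC2)cc1` differs from it by one change, cyclohexyl in place of methyl on an aromatic nitrogen. The same swap gave an at least 2.0-fold lower number from compound 1 to compound 2 (0.30 log units; that floor lies within the scatter). Amino in place of nitro gave an at least 5.0-fold lower number from compound 1 to compound 3 (0.69 log units; beyond the scatter), and compound 4 carries that amino group too. Both steps are only floors because of the limit of >= 100000 nM in this assay, at which 1 of the 3 values shown sits. A modest fall in the number is therefore expected, an estimated 2.0-fold lower number from compound 3 to compound 4 (0.30 log units; within the scatter). For compound 4 the estimate is 10000 nM, with an expected range from 3000 nM to 30000 nM.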

Compound 4, half-maximal cytotoxic concentration: 44000 nM
Estimate against measurement, compound 4: 4.4-fold (0.64 log units) below; measured number outside the range, above it.
By their numbers in this assay, from the lowest: compound 3; then compounds 4 and 2 (each within the scatter of the next). At a limit, above all of these: compound 1.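

On the amino compounds, cyclohexyl in place of methyl on the aromatic nitrogen gives a 2.2-fold higher number from compound 3 to compound 4 (0.34 log units; beyond the scatter) in this assay, so this swap does not read the same on every core: the same change on two cores in this assay, an at least 2.0-fold lower number (0.30 log units; that floor lies within the scatter) from compound 1 to compound 2 and a 2.2-fold higher number (0.34 log units; beyond the scatter) from compound 3 to compound 4, at least 4.4-fold (0.65 log units) apart, beyond the scatter of two such steps. With cyclohexyl on that nitrogen, amino in place of nitro gives only a 1.1-fold lower number from compound 2 to compound 4 (0.05 log units; within the scatter), far from what the methyl pair suggested: the same change on two cores in this assay, an at least 5.0-fold lower number (0.69 log units; beyond the scatter) from compound 1 to compound 3 and a 1.1-fold lower number (0.05 log units; within the scatter) from compound 2 to compound 4, at least 4.4-fold (0.65 log units) apart, beyond the scatter of two such steps. From the compounds shown here alone, the true size of both steps from compound 1 stays unknown: the limit of >= 100000 nM in this assay, at which 1 of the 4 values shown sits.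

The compounds shown leave open how an isopropyl or benzyl group on that nitrogen would read, and whether the amino and nitro compounds would again sit together.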